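From 2-methoxyphenyl to phenyl at the assay limit

The compounds below may be only part of what the source reports. "The series", "measured", "known", "first", "only" and "open" are said of these compounds alone.

In a functional assay on HepG2 cells (Homo sapiens) for inhibition, read by MTT assay, with a stated time of 48 h (on this read-out lower numbers stand for stronger inhibition and higher numbers for weaker inhibition), compound 1 `Fc1ccc(/C=N/Nc2nc(-c3ccc(F)c(F)c3)cs2)cc1F` gives 26600 nM. Compound 2 `COc1ccccc1-c1csc(N/N=C/c2ccc(F)c(F)c2)n1` reaches only a limit, > 100000 nM. Compound 3 `COc1ccccc1-c1csc(N/N=C/c2cc(OC)c(OC)c(Br)c2Br)n1` also reaches only a limit, > 100000 nM. Compound 2 therefore has no exact value and stands at the limit of > 100000 nM in this assay, at which 2 of the 3 values shown sit.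

Compound 4 `Fc1ccc(/C=N/Nc2nc(-c3ccccc3)cs2)cc1F` carries hydrogen in place of methoxy on an aromatic carbon, ortho to a large group (hydrogen in place of methoxy on an aromatic carbon). Among the compounds with values here, the one measured step bearing on this change is an at least 3.7-fold higher number from compound 1 to compound 2 (0.57 log units; beyond the scatter), and it introduced the same 2-methoxyphenyl in place of 3,4-difluorophenyl. On that evidence, a modest move towards a lower number is expected, namely an at least 2.0-fold lower number from compound 2 to compound 4 (0.30 log units; that floor lies within the scatter). For compound 4 the estimated value in this assay is 50000 nM, with an expected range of 15000 nM to 150000 nM.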

Compound 4, half-maximal inhibitory concentration: > 100000 nM
Compound 4 ended at the assay's limit; the forecaster's own chance of this, stated with the estimate: 35%; middle value at least 2.0-fold (0.30 log units) away from the limit.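

Compound 4 stays at a limit of this assay, so hydrogen in place of methoxy brings no readable gain, and the step between compound 2 and compound 4 cannot be read. The new information comes from the other side: phenyl in place of 3,4-difluorophenyl gives an at least 3.7-fold higher number from compound 1 to compound 4 (0.57 log units; beyond the scatter), so the methoxy is not needed for a number this high. Compound 4 sits at the same limit as compound 2: the limit of > 100000 nM in this assay, at which 3 of the 4 values shown sit.

Going by these compounds, how far apart compound 2 and compound 4 truly lie stays open. So does whether an amine or a carboxylic acid in place of the methoxy would return a measurable value.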